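The compounds below may be only part of what the source reports. "The series", "measured", "known", "first", "only" and "open" are said of these compounds alone.

Values in an ADME assay on BHK-21 cells (Mesocricetus auratus) for cytotoxicity, read by MTT assay; on this read-out lower numbers stand for higher toxicity in this test and higher numbers for lower toxicity in this test:
- compound 1 `CC(=O)c1ccc2[nH]c(-c3ccccc3)nc2c1`: > 100000 nM (a limit of the assay)
- compound 2 `C/C(=N\NC(N)=O)c1ccc2[nH]c(-c3ccccc3)nc2c1`: > 100000 nM (a limit of the assay)
- compound 3 `C/C(=N\NC(N)=S)c1ccc2[nH]c(-c3ccccc3)nc2c1`: 32000 nM

For the measured compounds named here, compound 3, at 32000 nM, holds the only actual number in the set. For compound 1 and compound 2, the reading is the limit of > 100000 nM in this assay, at which 2 of the 3 values shown sit. Both measured drops end at compound 3: an at least 3.1-fold lower number from compound 1 to compound 3 (0.49 log units; beyond the scatter) and an at least 3.1-fold lower number from compound 2 to compound 3 (0.49 log units; beyond the scatter). Each is only a minimum, since each starts from a limit. The comparison a step that the two limits leave unreadable from compound 1 to compound 2 adds nothing on size.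

Going by the values given here, compound 4 `C/C(=N\NC(N)=S)c1ccc2[nH]c(-c3ccoc3)nc2c1` keeps the group that compound 3 carries in place of the acetyl-derived groups of the earlier compounds. The one difference lies elsewhere: furan-3-yl in place of phenyl on an aromatic carbon. In words, this is furan-3-yl in place of phenyl on an aromatic carbon.

Among the compounds with values here, no measured step touches that phenyl, so neither drop gives a size for this change. They only make compound 3, at 32000 nM, the natural starting point for compound 4. Within the data shown here, with no measured precedent for the swap, no direction is favoured in this assay, and no step beyond the scatter is expected. The expected step is a 1.1-fold lower number from compound 3 to compound 4 (0.03 log units; within the scatter). For compound 4 the estimated value is 30000 nM, with an expected range of 11000 nM to 90000 nM.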

Compound 4, half-maximal cytotoxic concentration: > 100000 nM
Compound 4 gave a limit, no number (the forecaster's own chance of this, stated with the estimate: 20%); middle value at least 3.3-fold (0.52 log units) away from the limit.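

In this assay, the aromatic carbon between two ring nitrogen atoms is now shown to affect the read-out, as furan-3-yl in place of phenyl gives an at least 3.1-fold higher number from compound 3 to compound 4 (0.49 log units; beyond the scatter). The earlier compounds tied the lower number only to the change in the side chain, as in an at least 3.1-fold lower number from compound 2 to compound 3 (0.49 log units; beyond the scatter), whereas compound 4 shows that this side chain does not give a lower number with every ring at this place: of the two rings shown, only phenyl goes with it. The size of the new step remains a minimum, and compound 3 is still the only compound with an actual number: the limit of > 100000 nM in this assay, at which 3 of the 4 values shown sit.

As far as these compounds go, whether the ring oxygen or the change from six-membered to five-membered ring separates compound 4 from compound 3 stays open, and a thiophene or pyridine ring in place of phenyl would help to distinguish the two. The step from compound 1 to compound 2 cannot be read, and no order can be drawn among the compounds that sit at the limit.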